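This account rests on a few compounds, and the source may have more. Where it says the series, first, only, none or still open, it means among the compounds named here.

Compound 1 `Clc1ccc(Cn2cc(CCCOc3cccc4cccnc34)nn2)cc1`: 8.1 ug/mL
Compound 2 `FC(F)(F)Oc1ccc(Cn2cc(CCCOc3cccc4cccnc34)nn2)cc1`: 24.5 ug/mL

For the measured compounds named here, in a functional assay on OVCAR-3 cells (Homo sapiens) for inhibition, read by sulforhodamine B assay, with a stated time of 48 h (a higher number here means a weaker inhibitor of growth, a lower number a stronger inhibitor of growth), compound 2 gives 24.5 ug/mL, the higher of the two numbers so far, which makes it the weaker growth inhibitor of the pair. Compound 3 `c1ccc(Cn2cc(CCCOc3cccc4cccnc34)nn2)cc1` differs from it in one place: hydrogen in place of trifluoromethoxy on an aromatic carbon. In words, this is hydrogen in place of trifluoromethoxy on an aromatic carbon.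

Going by the values given here, one measured step bears on this change, at that same carbon: a 3.0-fold higher number from compound 1 to compound 2 (0.48 log units; beyond the scatter). Among the compounds with values here, that step is modest, and no measured compound yet carries hydrogen there, so the guide is thin. Going by compound 1 at 8.1 ug/mL, a compound without trifluoromethoxy can sit lower, so a modest move to a lower number is expected, perhaps not beyond the scatter. The estimated change is a 1.8-fold lower number from compound 2 to compound 3 (0.24 log units; within the scatter). For compound 3 the expected value is 14 ug/mL, with an estimated range of 5 ug/mL to 40 ug/mL.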

Compound 3, concentration for 50% growth inhibition: 24.3 ug/mL
The estimate for compound 3 lay 1.7-fold (0.24 log units) below the measured number; the range from low to high includes it.
By their numbers in this assay, from the lowest: compound 1; then compounds 3 and 2 (each within the scatter of the next).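

In this assay, hydrogen in place of trifluoromethoxy gives a 1.0-fold lower number from compound 2 to compound 3 (0.00 log units; within the scatter) and so makes no readable difference at this carbon, which sits para to a large group. Hydrogen in place of chloro gives a 3.0-fold higher number from compound 1 to compound 3 (0.48 log units; beyond the scatter) and shows what the first pair could not: compound 1 is the one that stands apart, while compound 2 simply matches the compound with no group there. Nothing measured here explains why chloro behaves differently.

Still open, going by these compounds, is whether this lower number belongs to chloro alone or would also appear with fluoro or bromo. It is equally unknown whether a methoxy group, an amine or a carboxylic acid at this carbon would side with compound 1 or with compound 3.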